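A few compounds are considered here, and "the series" means these few. Any claim that something is new, unique, unknown or untested is made for them only; others in the source may bear on it.

In a physicochemical assay, read by spectrophotometry, with a stated time of 30 min (on this read-out lower numbers stand for stronger inhibition and higher numbers for weaker inhibition), compound 1 `O=[N+]([O-])c1cccc(Cn2cc(COc3ccccc3)nn2)c1` gives 25.3 ug/mL and compound 2 `O=[N+]([O-])c1cccc(Cn2cc(COc3cccc([N+](=O)[O-])c3)nn2)c1` gives 19.1 ug/mL. Going by the values given here, the only measured step, nitro in place of hydrogen on an aromatic carbon, is a 1.3-fold lower number from compound 1 to compound 2 (0.12 log units; within the scatter), so these two values cannot be told apart. Compound 3 `O=[N+]([O-])c1cccc(OCc2cn(Cc3cccc(Cl)c3)nn2)c1` differs from compound 2 by chloro in place of nitro on an aromatic carbon, meta to a large group. Among the compounds with values here, no measured step exchanges these two groups, so no shift beyond the scatter is expected in this assay. The expected change is a 1.0-fold higher number from compound 2 to compound 3 (0.02 log units; within the scatter). The estimate for compound 3 is 20 ug/mL, with an expected range of 10 ug/mL to 40 ug/mL.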

Compound 3, half-maximal inhibitory concentration: 31.2 ug/mL
Compound 3: middle estimate off by 1.6-fold (0.19 log units), on the low side; measured number inside the range.
By their numbers in this assay, from the lowest: compounds 2, 1 and 3 (each within the scatter of the next).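

In this assay the change at this place, an aromatic carbon meta to a large group, reads as a 1.6-fold higher number from compound 2 to compound 3 (0.21 log units; within the scatter). So far, this position has taken chloro in place of nitro, a single heavy atom for three and no hydrogen-bond acceptors for two, without a shift that can be told from the scatter. No evidence at hand bears on this result.

Going by these compounds, whether an amine or a carboxylic acid on this same aromatic carbon would move the number beyond the scatter stays open. So does the effect of a longer chain here.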